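Anilino in place of ethoxy on the selenium series

The source may report more compounds than this note shows. Statements on the series, on what has been measured and on what is new or still open speak of the compounds shown alone.

In a functional assay on T47D cells (Homo sapiens) for inhibition, read by sulforhodamine B assay, with a stated time of 48 h (a lower number here means a stronger inhibitor of growth, a higher number a weaker inhibitor of growth), compound 1 `CCOC(=[Se])Nc1ccc2c(C)cc(=O)oc2c1` gives > 100000 nM, which is a limit of the assay and not a number. Compound 1 therefore stands at the limit of > 100000 nM in this assay, at which 1 of the 3 values shown sits. Compound 2 `CCCOC(=[Se])Nc1ccc2c(C)cc(=O)oc2c1` gives 41000 nM, and compound 3 `CCCCNC(=[Se])Nc1ccc2c(C)cc(=O)oc2c1` gives 2900 nM.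

Compound 4 `Cc1cc(=O)oc2cc(NC(=[Se])Nc3ccccc3)ccc12` is not yet measured. It differs from compound 1 as follows: anilino in place of ethoxy on a saturated chain carbon bound to a nitrogen on an aromatic ring. The closest precedents are the butylamino replacements, which also put a nitrogen-linked group in place of an oxygen-linked one: an at least 34-fold lower number from compound 1 to compound 3 (1.53 log units; beyond the scatter) and a 14-fold lower number from compound 2 to compound 3 (1.15 log units; beyond the scatter), both large. The propoxy change is smaller, at an at least 2.4-fold lower number from compound 1 to compound 2 (0.38 log units; beyond the scatter), and bears less directly. Butylamino has no ring, whereas anilino enters with one six-membered aromatic ring of carbon only, so the precedent is imperfect and the range stays wide. A large step to a lower number is expected in this assay. The estimated step is an at least 25-fold lower number from compound 1 to compound 4 (1.39 log units; beyond the scatter). For compound 4 the expected value is 4000 nM, with an estimated range of 800 nM to 20000 nM.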

Compound 4, concentration for 50% growth inhibition: 24000 nM
Compound 4: the middle estimate sits 6.0-fold (0.78 log units) below what was measured, and the stated range ends below it.
By their numbers in this assay, from the lowest: compound 3; then compounds 4 and 2 (each within the scatter of the next). At a limit, above all of these: compound 1.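

Compound 1 stands at a limit of the assay and not a number: the limit of > 100000 nM in this assay, at which 1 of the 4 values shown sits. In this assay, anilino in place of ethoxy still gives an at least 4.1-fold lower number from compound 1 to compound 4 (0.61 log units; beyond the scatter), so this step sets only a bound, but it shows that a ring-bearing nitrogen group at this place keeps a lower number than the limit. Phenyl in place of butyl on the amine nitrogen gives an 8.3-fold higher number from compound 3 to compound 4 (0.92 log units; beyond the scatter), so the group carried by that nitrogen matters and a nitrogen link alone does not reproduce compound 3, while anilino in place of propoxy gives a 1.7-fold lower number from compound 2 to compound 4 (0.23 log units; within the scatter).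

On these data alone, whether a benzyl group or a longer chain such as hexyl on the amine nitrogen would match or pass compound 3 stays open. So does whether a chlorophenyl group would differ from phenyl.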